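The source may hold more compounds than are shown below. What is called first, only, known or untested is meant among the compounds shown, and "the series" means these compounds.

Measured compounds:
compound 1, `COc1ccnc(C(=O)Nc2nn[nH]n2)c1`, 88%
compound 2, `O=C(Nc1nn[nH]n1)c1ccccn1`, 35%

Among the compounds with values here, in a functional assay on the whole organism for inhibition, with Rattus norvegicus as the target, at a dose of 10 mg/kg by the oral route (on this read-out lower numbers stand for a weaker effect and higher numbers for a stronger effect at the one dose given), compound 2 gives 35%, the lower of the two numbers so far, while compound 1 gives 88%. Within the data shown here, the one step between them, a number 53 percentage points lower from compound 1 to compound 2 (beyond the scatter), shows how much is lost when the methoxy is replaced by hydrogen on an aromatic carbon. Compound 3, `CCCCc1ccnc(C(=O)Nc2nn[nH]n2)c1`, has not yet been measured. It differs from compound 2 by butyl in place of hydrogen on an aromatic carbon. Among the measured compounds shown here, the only measured step that bears on this change is a number 53 percentage points lower from compound 1 to compound 2 (beyond the scatter), which involved a methoxy rather than a butyl, so its size cannot simply be carried over. Still, a group added on that aromatic carbon is expected to raise the number, and compound 3 is estimated to lie above compound 2 by a number 30 percentage points higher from compound 2 to compound 3 (beyond the scatter), with wide uncertainty. The estimate for compound 3 is 65%, within 35% to 90%.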

Compound 3, a percentage reported as inhibition, in the whole organism at one dose (the size of the read-out at that dose, not a potency): 54%
For compound 3 the middle estimate is 11 percentage points above the measured one; low and high end bracket the measured number.
By their numbers in this assay, from the lowest: compound 2; then compound 3; then compound 1.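

In this assay, within the data shown here, putting butyl in place of hydrogen on the aromatic carbon opposite the ring nitrogen gives a number 19 percentage points higher from compound 2 to compound 3 (beyond the scatter) and so shows that methoxy is not the only group that can raise the number at this position. The choice of group still matters, since changing methoxy to butyl on the same core gives a number 34 percentage points lower from compound 1 to compound 3 (beyond the scatter) and leaves butyl well short of methoxy. Nothing available here explains why these two groups differ.

The compounds shown cannot tell whether the higher number of compound 1 depends on the oxygen of the methoxy or on something else about that group. An ethoxy, an amine or a longer chain such as hexyl at this same carbon would help to separate these possibilities.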